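The compounds below may be only part of what the source reports. "The series", "measured", "known", "first", "only" and "open" are said of these compounds alone.

Three compounds of a shared core have been examined in a functional assay on MKN-45 cells (Homo sapiens) for cytotoxicity, read by MTT assay, with a stated time of 72 h; a higher number here means a weaker inhibitor, a lower number a stronger inhibitor. Compound 1 `COc1cc2c(Oc3ccc(NC(=O)c4cn(-c5ccc(Cl)cc5)cn4)cc3F)ccnc2cc1OCCCN1CCCCC1` gives 5910 nM in this assay. Compound 2 `COc1cc2c(Oc3ccc(NC(=O)/C=C/S(=O)(=O)c4ccc(C)cc4)cc3F)ccnc2cc1OCCCN1CCN(C)CC1` gives 2510 nM in this assay. Compound 3 `COc1ccc(S(=O)(=O)/C=C/C(=O)Nc2ccc(Oc3ccnc4cc(OCCCN5CCCCC5)c(OC)cc34)c(F)c2)cc1` gives 3580 nM in this assay, which places it second highest of the three numbers; its nearest neighbour is compound 2, whose number is lower by an amount within the scatter, and its furthest is compound 1, whose number is higher by an amount that is also within the scatter. None of the three, therefore, can be set apart from the others.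

Compound 4 `COc1cc2c(Oc3ccc(NC(=O)/C=C/S(=O)(=O)c4ccc(C)cc4)cc3F)ccnc2cc1OCCCN1CCCCC1` has not yet been measured. It differs from compound 3 by methyl in place of methoxy on an aromatic carbon, placed on an aromatic carbon of a six-membered aromatic ring of carbon only, para to a large group: the (4-methoxyphenyl)sulfonyl becomes a (4-methylphenyl)sulfonyl. For the measured compounds named here, no measured pair shows this change in isolation. Compound 2 carries the same (4-methylphenyl)sulfonyl with a different chain end and gives 2510 nM, so the step is expected to be small. The expected step from compound 3 to compound 4 is a 1.2-fold lower number from compound 3 to compound 4 (0.09 log units; within the scatter), not beyond the scatter. Compound 4 is accordingly estimated at 2900 nM, with a range from 1200 nM to 7000 nM.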

Compound 4, half-maximal inhibitory concentration: 1690 nM
The estimate for compound 4 lay 1.7-fold (0.23 log units) above the measured number; the range from low to high includes it.
By their numbers in this assay, from the lowest: compounds 4, 2, 3 and 1 (each within the scatter of the next, the first and the last beyond it).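

In this assay, methyl in place of methoxy on an aromatic carbon, para to a large group, gives a 2.1-fold lower number from compound 3 to compound 4 (0.33 log units; beyond the scatter) and so gives this position its first single-change step, a modest one that stands beyond the scatter. The other two steps fill in the picture: piperidin-1-yl in place of 4-methylpiperazin-1-yl gives a 1.5-fold lower number from compound 2 to compound 4 (0.17 log units; within the scatter) and stays within the scatter, while 2-((4-methylphenyl)sulfonyl)ethenyl in place of 1-(4-chlorophenyl)-1H-imidazol-4-yl on a carbonyl carbon gives a 3.5-fold lower number from compound 1 to compound 4 (0.54 log units; beyond the scatter) and is again modest and beyond it. Nothing available accounts for any of these steps.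

The compounds shown leave open how chlorine, trifluoromethyl or a dimethylamino group would read at this place on the ring. As far as these compounds go, whether the methyl-for-methoxy step also holds with a 4-methylpiperazin-1-yl chain end remains open too.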